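The compounds below may be only part of what the source reports. "The series", "measured", "known", "first", "only" and "open" are said of these compounds alone.

Measured so far in a functional assay on MDA-MB-231 cells (Homo sapiens) for antiproliferative activity, read by MTT assay, with a stated time of 24 h; a lower number here means a stronger inhibitor, a higher number a weaker inhibitor:
- compound 1 `O=C(NNc1ccccc1Cl)c1ccc(NS(=O)(=O)c2cnc(O)nc2O)cc1`: 4010 nM
- compound 2 `CCCCOc1ccc(C(=O)NNC(=O)c2ccc(NS(=O)(=O)c3cnc(O)nc3O)cc2)cc1`: 11900 nM
- compound 3 `Cc1ccccc1C(=O)NNC(=O)c1ccc(NS(=O)(=O)c2cnc(O)nc2O)cc1`: 7040 nM

Compound 3 gives 7040 nM, a number within the scatter of both compound 1 and compound 2. Next in the series is compound 4 `O=C(NNC(=O)c1ccccc1F)c1ccc(NS(=O)(=O)c2cnc(O)nc2O)cc1`, which differs from compound 3 by one change: fluoro in place of methyl on an aromatic carbon. This is fluoro in place of methyl on an aromatic carbon, ortho to a large group.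

Among the measured compounds shown here, two measured steps bear on this end of the molecule: a 1.7-fold lower number from compound 2 to compound 3 (0.23 log units; within the scatter) and a 1.8-fold higher number from compound 1 to compound 3 (0.24 log units; within the scatter). Both are wider changes than the one here, and both stay within the scatter. For the measured compounds named here, no measured pair isolates this exact swap, so no direction can be assigned in this assay, and no step beyond the scatter is expected.

For this change the estimate is a 1.1-fold lower number from compound 3 to compound 4 (0.03 log units; within the scatter), an expected step that stays within the scatter. The expected value for compound 4 is 6500 nM, with an estimated range of 3000 nM to 14000 nM.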

Compound 4, half-maximal inhibitory concentration: > 20000 nM
Compound 4 ended at the assay's limit (the forecaster's own chance of this, stated with the estimate: 3%); at least 3.0-fold (0.48 log units) between middle value and limit.
By their numbers in this assay, from the lowest: compounds 1, 3 and 2 (each within the scatter of the next, the first and the last beyond it). At a limit, above all of these: compound 4.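

In this assay compound 4 reads > 20000 nM, which is a limit of the assay and not a number: the limit of > 20000 nM in this assay, at which 1 of the 4 values shown sits. This shows that the aromatic carbon ortho to a large group is sensitive to a swap of one heavy atom, with fluoro in place of methyl giving an at least 2.8-fold higher number from compound 3 to compound 4 (0.45 log units; beyond the scatter), and the comparison with the 2-chlorophenyl compound gives an at least 4.9-fold higher number from compound 1 to compound 4 (0.69 log units; beyond the scatter). The comparison with the 4-butoxyphenyl compound gives only an at least 1.6-fold higher number from compound 2 to compound 4 (0.22 log units; that floor lies within the scatter), so the order of that pair stays unsettled.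

From the compounds shown here alone, how far compound 4 lies past the limit remains open, so the true size of all three steps is unknown. Also open, going by these compounds, is how a methoxy group, an amine or a hydrogen on this same carbon would read, and so whether methyl is specifically favoured here.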